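Working notes: removing one trifluoromethyl group

This account rests on a few compounds, and the source may have more. Where it says the series, first, only, none or still open, it means among the compounds named here.

Measured in a functional assay on MOLT-4 cells (Homo sapiens) for inhibition, read by MTT assay, with a stated time of 72 h; on this read-out lower numbers stand for stronger inhibition and higher numbers for weaker inhibition:
- compound 1 (`COc1cc(NC(C)CCCNC(=O)Nc2ccc(F)cc2)c2ncccc2c1`) gives (24000 nM)
- compound 2 (`COc1cc(NC(C)CCCNC(=O)Nc2cc(C(F)(F)F)cc(C(F)(F)F)c2)c2ncccc2c1`) gives (12000 nM)

Compound 2 has the lowest number of the two, but its gap to compound 1 lies within the usual scatter of repeat measurements, so the pair cannot be separated in this assay on these data.

Compound 3 (`COc1cc(NC(C)CCCNC(=O)Nc2cccc(C(F)(F)F)c2)c2ncccc2c1`) is the next to be read. It keeps the core of compound 2 and carries hydrogen in place of trifluoromethyl on an aromatic carbon. Within the data shown here, no measured pair isolates this change, so the expectation rests on two compounds only. Compound 1 (24000 nM) and compound 2 (12000 nM) differ in the groups on the six-membered aromatic ring of carbon only, yet stay within the scatter of each other. No step beyond the scatter is therefore expected in either direction. The expected change is small (a 1.3-fold higher number from compound 2 to compound 3 (0.10 log units; within the scatter)) and is an estimate only. For compound 3 the estimated value is 15000 nM with an expected range from 7000 nM to 32000 nM in this assay.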

Compound 3, half-maximal inhibitory concentration: 20000 nM
For compound 3 the middle estimate is 1.3-fold (0.12 log units) below the measured one; the measured number falls inside the stated range.
By their numbers in this assay, from the lowest: compounds 2, 3 and 1 (each within the scatter of the next).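

In this assay, among these compounds, hydrogen in place of trifluoromethyl on an aromatic carbon, meta to a trifluoromethyl group, gives a 1.7-fold higher number from compound 2 to compound 3 (0.22 log units; within the scatter), the first step that isolates a single group at this position; at this position, compound 2 and compound 3 cannot be separated, and the trifluoromethyl group shows no effect that can be read. The other step, with 3-(trifluoromethyl)phenyl in place of 4-fluorophenyl on an amide-type nitrogen, gives a 1.2-fold lower number from compound 1 to compound 3 (0.08 log units; within the scatter), so compound 3, at 20000 nM, cannot be separated from compound 1 either. All three aromatic substitution patterns shown therefore stay within the scatter of one another in this assay, and no information on why this is so accompanies these numbers.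

Open, from the compounds shown here alone, is whether a different group at this position, such as an amine, a carboxylic acid or a methoxy group, would give a step beyond the scatter. Also open, going by these compounds, is whether a change away from this aromatic ring, such as a longer chain between the shared core and the amide-type nitrogen, would separate compounds in this assay.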